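Compound 4: a bromophenyl replaces the chlorophenyl of compound 3

This account rests on a few compounds, and the source may have more. Where it says the series, first, only, none or still open, it means among the compounds named here.

Of the compounds shown here, three that share one core have been measured in a functional assay on LoVo cells (Homo sapiens) for inhibition, read by MTT assay, with a stated time of 24 h; on this read-out higher numbers stand for weaker inhibition and lower numbers for stronger inhibition. Compound 1 `COc1ccccc1-n1cc(CN2C(=O)C[C@@H]3CC[C@@]2(C)C3(C)C)nn1` gives 70 nM, compound 2 `Cc1ccc(-n2cc(CN3C(=O)C[C@@H]4CC[C@@]3(C)C4(C)C)nn2)cc1` gives 50 nM, and compound 3 `CC1(C)[C@H]2CC[C@]1(C)N(Cc1cn(-c3ccccc3Cl)nn1)C(=O)C2` gives 190 nM. Compound 3 thus carries the highest number of the three: there is a 2.7-fold higher number from compound 1 to compound 3 (0.43 log units; beyond the scatter) and a 3.8-fold higher number from compound 2 to compound 3 (0.58 log units; beyond the scatter), both beyond the scatter, whereas a 1.4-fold lower number from compound 1 to compound 2 (0.15 log units; within the scatter).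

Compound 4 `CC1(C)[C@H]2CC[C@]1(C)N(Cc1cn(-c3ccc(Br)cc3)nn1)C(=O)C2` differs from compound 3 in one place: 4-bromophenyl in place of 2-chlorophenyl on an aromatic nitrogen. The step that bears most directly on this change runs from compound 2 to compound 3, where a 4-methylphenyl gave way to a 2-chlorophenyl and the number rose modestly. The 4-bromophenyl of compound 4 resembles the 4-methylphenyl of compound 2 more than the 2-chlorophenyl of compound 3, so a modest move back toward a lower number is expected, roughly a 2.7-fold lower number from compound 3 to compound 4 (0.43 log units; beyond the scatter). Compound 4 is therefore estimated at 70 nM, with a range from 30 nM to 200 nM.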

Compound 4, half-maximal inhibitory concentration: 60 nM
Estimate against measurement, compound 4: 1.2-fold (0.07 log units) above; measured number inside the range.
By their numbers in this assay, from the lowest: compounds 2, 4 and 1 (each within the scatter of the next); then compound 3.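

The step of a 3.2-fold lower number from compound 3 to compound 4 (0.50 log units; beyond the scatter) in this assay shows that a halogen-bearing phenyl on this aromatic nitrogen need not carry the high number of compound 3. The steps of a 1.2-fold higher number from compound 2 to compound 4 (0.08 log units; within the scatter) and a 1.2-fold lower number from compound 1 to compound 4 (0.07 log units; within the scatter) both lie within the scatter, so here the 4-bromophenyl cannot be told apart from the 4-methylphenyl or the 2-methoxyphenyl. Nothing measured here explains why the 2-chlorophenyl stands apart from these groups.

This step changes both the halogen and its place on the phenyl, so the compounds shown cannot separate the two changes, which a 4-chlorophenyl or a 2-bromophenyl could help to do. As far as these compounds go, how a phenyl bearing an amine or a carboxylic acid would behave at this position also remains open.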